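One Changed Aryl Group on a Shared Core

This account rests on a few compounds, and the source may have more. Where it says the series, first, only, none or still open, it means among the compounds named here.

Of the compounds shown here, two built on the same core have been tested for their power to kill prostate cancer cells. Among the compounds with values here, in a functional assay on PC-3 cells (Homo sapiens) for cytotoxicity, read by MTT assay, with a stated time of 72 h (on this read-out higher numbers stand for weaker inhibition and lower numbers for stronger inhibition), compound 1 `O=C(N/N=C/c1ccc([N+](=O)[O-])cc1)Nc1cc2c(Nc3ccc(F)c(Cl)c3)ncnc2cc1O[C@H]1CCOC1` gives 33500 nM, the highest of the two numbers known so far. In this assay compound 2 `COc1ccc(/C=N/NC(=O)Nc2cc3c(Nc4ccc(F)c(Cl)c4)ncnc3cc2O[C@H]2CCOC2)c(OC)c1OC` gives 25600 nM. Within the data shown here, the only measured step, a 1.3-fold lower number from compound 1 to compound 2 (0.12 log units; within the scatter), exchanges the 4-nitrophenyl for a 2,3,4-trimethoxyphenyl on a carbon with a double bond to nitrogen, and its size sits inside the scatter, so the two numbers cannot be told apart.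

Compound 3 `CCN(CC)c1ccc(/C=N/NC(=O)Nc2cc3c(Nc4ccc(F)c(Cl)c4)ncnc3cc2O[C@H]2CCOC2)c(O)c1` has not been measured. It differs from compound 1 at the very same place: 4-(diethylamino)-2-hydroxyphenyl in place of 4-nitrophenyl on a carbon with a double bond to nitrogen. Among the measured compounds shown here, only the step from compound 1 to compound 2 bears on this change, since it alters the same aryl group, and that step stayed within the scatter. No step beyond the scatter is therefore expected in this assay for compound 3, in either direction. The estimated step is a 1.2-fold lower number from compound 1 to compound 3 (0.08 log units; within the scatter). For compound 3 the expected value is 28000 nM, with a range from 10000 nM to 80000 nM.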

Compound 3, half-maximal inhibitory concentration: 4590 nM
The estimate for compound 3 lay 6.1-fold (0.79 log units) above the measured number; measured number below the stated range.
By their numbers in this assay, from the lowest: compound 3; then compounds 2 and 1 (each within the scatter of the next).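

In this assay the aryl group on a carbon with a double bond to nitrogen clearly can change the result: 4-(diethylamino)-2-hydroxyphenyl in place of 4-nitrophenyl gives a 7.3-fold lower number from compound 1 to compound 3 (0.86 log units; beyond the scatter), and in place of 2,3,4-trimethoxyphenyl it gives a 5.6-fold lower number from compound 2 to compound 3 (0.75 log units; beyond the scatter). The step between the two earlier compounds stayed within the scatter, whereas these two steps lie beyond it and point the same way, towards stronger inhibition, whichever of the other two aryl groups is replaced. No measurement here explains why the number falls with this change.

The compounds shown leave open which part of the entering group matters, since the diethylamino group and the hydroxy group occur only together here. An aryl group carrying the diethylamino group alone, one carrying the hydroxy group alone, or one with a dimethylamino group in place of the diethylamino group would help to separate their contributions.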